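Replacing amino with nitro in a small series

A few compounds are considered here, and "the series" means these few. Any claim that something is new, unique, unknown or untested is made for them only; others in the source may bear on it.

Measured in an ADME assay on the whole organism (muscle tissue) for activation, with Mus musculus as the target, in the rotarod test, with a stated time of 30 min; a lower number here means that less compound is needed, a higher number that more compound is needed for the effect:
- compound 1 `N#Cc1ccc(-c2ccc(/C=N/N3C(=O)NC(=O)C3O)o2)cc1`: 96 mg/kg
- compound 2 `CC(=O)Nc1ccc(-c2ccc(/C=N/N3C(=O)NC(=O)C3O)o2)cc1`: > 1000 mg/kg (a limit)
- compound 3 `Nc1ccc(-c2ccc(/C=N/N3C(=O)NC(=O)C3O)o2)cc1`: > 1000 mg/kg (a limit)

Compound 3 has no exact number, only the limit > 1000 mg/kg. This is the limit of > 1000 mg/kg in this assay, at which 2 of the 3 values shown sit.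

The next compound, compound 4 `O=C1NC(=O)N(/N=C/c2ccc(-c3ccc([N+](=O)[O-])cc3)o2)C1O`, has not yet been measured. It carries nitro in place of amino on an aromatic carbon.

Going by the values given here, no measured step involves nitro, so the guide is indirect. Among the compounds with values here, the steps that bear on this change start from the nitrile of compound 1, which gives 96 mg/kg. They are an at least 10-fold higher number from compound 1 to compound 3 (1.01 log units; beyond the scatter) and an at least 10-fold higher number from compound 1 to compound 2 (1.01 log units; beyond the scatter), and both are large. The step that the two limits leave unreadable from compound 2 to compound 3 adds nothing. Within the data shown here, compound 1 is the only measured compound with a number, and its nitrile sits where compound 4 has nitro, so nitro may behave more like nitrile than amino, though this is only a working guess.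

On that basis, the expected change is large and towards less compound needed: an at least 6.6-fold lower number from compound 3 to compound 4 (0.82 log units; beyond the scatter). A limit could still be the result.

The estimate for compound 4 is 150 mg/kg, with an expected range from 40 mg/kg to 600 mg/kg.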

Compound 4, dose for half-maximal effect: 171 mg/kg
Estimate against measurement, compound 4: 1.1-fold (0.06 log units) below, within the range that was stated.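

In this assay, nitro on this aromatic carbon, para to a large group, gives a readable number where amino and acetamido do not: an at least 5.8-fold lower number from compound 3 to compound 4 (0.76 log units; beyond the scatter), and an at least 5.8-fold lower number from compound 2 to compound 4 (0.76 log units; beyond the scatter). Nitro and nitrile cannot be told apart at this position, with a 1.8-fold higher number from compound 1 to compound 4 (0.25 log units; within the scatter), so a second group now gives a readable number here. Across these four compounds, amino and acetamido give only a limit while nitrile and nitro give numbers, and no compound shown goes against this split.

The first two steps show only a smallest possible size, because compound 2 and compound 3 each carry a limit and not a number: the limit of > 1000 mg/kg in this assay, at which 2 of the 4 values shown sit. Whether the split extends to other groups on this carbon, such as a carboxylic acid or trifluoromethyl, stays open, as does what lies behind it.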